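A few compounds are considered here, and "the series" means these few. Any claim that something is new, unique, unknown or untested is made for them only; others in the source may bear on it.

Compound 1 `COc1cccc(F)c1CNC(=O)c1[nH]c2ccc(Cl)cc2c1S(=O)(=O)c1cc(C)cc(C)c1` in an ADME assay on MT4 cells (Homo sapiens) for cytotoxicity, read by MTT assay (on this read-out lower numbers stand for higher toxicity in this test and higher numbers for lower toxicity in this test), gives only a limit of the assay, > 49900 nM.
Compound 2 `Cc1cc(C)cc(S(=O)(=O)c2c(C(=O)NC(C)C(=O)NC(C)c3ccccc3)[nH]c3ccc(Cl)cc23)c1` in this assay gives 21700 nM.
Compound 3 `Cc1cc(C)cc(S(=O)(=O)c2c(C(=O)NC(C)C(=O)NCc3ccncc3)[nH]c3ccc(Cl)cc23)c1` in this assay gives 19500 nM.

Among the two numbers shown, compound 3 stands lowest, with compound 2 nearest; the two lie within the scatter of each other, so no order between them can be read. Compound 4 `Cc1cc(C)cc(S(=O)(=O)c2c(C(=O)NC(C)C(=O)NCc3ccncn3)[nH]c3ccc(Cl)cc23)c1` differs from compound 3 in one place: pyrimidin-4-yl in place of pyridin-4-yl on a saturated chain carbon bound to an amide-type nitrogen.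

Going by the values given here, two measured steps bear on this position. The step of an at least 2.5-fold lower number from compound 1 to compound 3 (0.40 log units; beyond the scatter) shows that a larger exchange at this end of the molecule can move the number, though the comparison rests on a limit for compound 1 (the limit of > 49900 nM in this assay, at which 1 of the 3 values shown sits). The step of a 1.1-fold lower number from compound 2 to compound 3 (0.05 log units; within the scatter) shows that exchanging one aromatic group for another at the same amide-type nitrogen left the number essentially unchanged. The change from compound 3 to compound 4 is smaller still, a single ring carbon exchanged for a nitrogen within an otherwise identical (pyrimidin-4-yl)methyl group, so a step of no more than the scatter is expected in this assay, with no clear direction.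

Compound 4 is therefore estimated at 20000 nM in this assay, within 9000 nM to 45000 nM, which corresponds to an expected step of a 1.0-fold higher number from compound 3 to compound 4 (0.01 log units; within the scatter).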

Compound 4, half-maximal cytotoxic concentration: 28100 nM
Compound 4: middle estimate off by 1.4-fold (0.15 log units), on the low side, and the stated range covers the measured number.
By their numbers in this assay, from the lowest: compounds 3, 2 and 4 (each within the scatter of the next). At a limit, above all of these: compound 1.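

In this assay, pyrimidin-4-yl in place of pyridin-4-yl on a saturated chain carbon bound to an amide-type nitrogen gives a 1.4-fold higher number from compound 3 to compound 4 (0.16 log units; within the scatter), so this exchange of a single ring atom has no readable effect on the number. The second step, a 1.3-fold higher number from compound 2 to compound 4 (0.11 log units; within the scatter), is also within the scatter, and compound 2, compound 3 and compound 4 therefore cannot be ordered, whether the amide-type nitrogen carries 1-phenylethyl, (pyridin-4-yl)methyl or (pyrimidin-4-yl)methyl at the end of its group. The third step, an at least 1.7-fold lower number from compound 1 to compound 4 (0.24 log units; that floor lies within the scatter), rests on a limit for compound 1 and its floor lies within the scatter, unlike the step from compound 1 to compound 3, so it cannot be read as a difference: the limit of > 49900 nM in this assay, at which 1 of the 4 values shown sits.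

The compounds shown leave open whether an amine or a carboxylic acid on this ring, or a longer chain between the amide-type nitrogen and the ring, would move the number in this assay beyond the scatter. Also open, going by these compounds, is how far compound 1 truly lies from the other three, as its value is only a limit.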